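Cytotoxicity outlook for a dimethylsulfamoyl analogue

The source may hold more compounds than are shown below. What is called first, only, known or untested is meant among the compounds shown, and "the series" means these compounds.

Three macrocyclic compounds have been measured in an ADME assay on cells (Homo sapiens) for activation; on this read-out higher numbers stand for lower toxicity in this test and lower numbers for higher toxicity in this test. Compound 1 `CCCn1cc(-c2cc(OCC[C@@H]3NC(=O)N(C)CCCC/C=C\[C@@H]4C[C@@]4(C(=O)NS(=O)(=O)C4(C)CC4)NC3=O)c3ccc(OC)c(C)c3n2)cn1` gives 62300 nM in this assay. Compound 2 `COc1ccc2c(OCC[C@@H]3NC(=O)N(C)CCCC/C=C\[C@@H]4C[C@@]4(C(=O)NS(=O)(=O)C4CC4)NC3=O)cc(-c3nc(C(C)C)cs3)nc2c1Cl` gives 40400 nM in this assay, the lower of the two plain numbers, though compound 1 as its nearest neighbour lies within the usual scatter of it. For compound 3 `COc1ccc2c(OCC[C@@H]3NC(=O)N(C)CCCC/C=C\[C@@H]4C[C@@]4(C(=O)NS(=O)(=O)C4CC4)NC3=O)cc(-c3nc(C(C)C)cs3)nc2c1F` the result in this assay is a limit of the assay, > 75000 nM. The only single-point step among these, an at least 1.8-fold higher number from compound 2 to compound 3 (0.26 log units; that floor lies within the scatter), has its floor set by the limit of > 75000 nM in this assay, at which 1 of the 3 values shown sits.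

Compound 4 `COc1ccc2c(OCC[C@@H]3NC(=O)N(C)CCCC/C=C\[C@@H]4C[C@@]4(C(=O)NS(=O)(=O)N(C)C)NC3=O)cc(-c3nc(C(C)C)cs3)nc2c1Cl` is derived from compound 2 by a single change: dimethylamino in place of cyclopropyl on a sulfonyl sulfur. Within the data shown here, no measured step touches the sulfonyl sulfur; the step from compound 2 to compound 3 concerns a halogen on an aromatic carbon and so offers no direct guide to this exchange. All three measured results lie in the same high region, and nothing in the data points to a shift in either direction beyond the scatter for this change. The expected step is therefore a 1.1-fold higher number from compound 2 to compound 4 (0.05 log units; within the scatter), a shift within the usual scatter. For compound 4 the estimated value in this assay is 45000 nM, with a range from 20000 nM to 75000 nM.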

Compound 4, half-maximal cytotoxic concentration: 47800 nM
The estimate for compound 4 lay 1.1-fold (0.03 log units) below the measured number; measured number inside the range.
By their numbers in this assay, from the lowest: compounds 2, 4 and 1 (each within the scatter of the next). At a limit, above all of these: compound 3.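

In this assay, the exchange of cyclopropyl for dimethylamino on a sulfonyl sulfur gives a 1.2-fold higher number from compound 2 to compound 4 (0.07 log units; within the scatter), the only measured step at this position among the compounds shown. The step from compound 2 to compound 3 concerned a halogen on an aromatic carbon, whereas this result shows that, on the chloro compound, an open group with a nitrogen on the sulfonyl sulfur can replace the three-membered carbon ring, with the same count of heavy atoms, and leave the number within the scatter. Nothing measured here explains why the exchange leaves the number within the scatter.

Going by these compounds, a single exchange cannot show whether a larger group on the sulfonyl sulfur, such as morpholine, diethylamino or a phenyl ring, would also stay within the scatter of compound 2, so the tolerance of this position remains open beyond dimethylamino. On these data alone, compound 3 stands at a limit of the assay, > 75000 nM, and how dimethylamino on the sulfonyl sulfur would read with fluoro in place of chloro also stays open.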